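Halogen removal at the aminobenzamide position

A few compounds are considered here, and "the series" means these few. Any claim that something is new, unique, unknown or untested is made for them only; others in the source may bear on it.

Measured so far:
compound 1 `CCCCN1CCC(CNC(=O)c2cc(Cl)c(N)c3[nH]cnc23)CC1`: 22.4 nM
compound 2 `CCCCN1CCC(CNC(=O)c2cc(Br)c(N)c3[nH]cnc23)CC1`: 27.8 nM

In an assay on membranes from striatum for binding affinity to 5-hydroxytryptamine receptor 4 (Rattus norvegicus) (a higher number here means a weaker inhibitor, a lower number a stronger inhibitor), compound 2 gives 27.8 nM, the higher of the two numbers, yet the step of a 1.2-fold higher number from compound 1 to compound 2 (0.09 log units; within the scatter) lies within the scatter, so the two stand level. Compound 3 `CCCCN1CCC(CNC(=O)c2ccc(N)c3[nH]cnc23)CC1` is unmeasured; it differs from compound 2 by hydrogen in place of bromo on an aromatic carbon, at the carbon ortho to an amino group. Going by the values given here, no measured step removes the halogen outright; the bromo-for-chloro swap shows only that the two halogens are interchangeable here, so it bears weakly on this step. A loss of affinity is nevertheless expected for compound 3, with a 5.4-fold higher number from compound 2 to compound 3 (0.73 log units; beyond the scatter) as the estimated step, giving an estimate of 150 nM (range 40 nM to 600 nM).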

Compound 3, inhibition constant: 115 nM
Estimate against measurement, compound 3: 1.3-fold (0.12 log units) above; low and high end bracket the measured number.
By their numbers in this assay, from the lowest: compounds 1 and 2 (each within the scatter of the next); then compound 3.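

In this assay, replacing the halogen with hydrogen on the carbon ortho to an amino group costs affinity, with a 4.1-fold higher number from compound 2 to compound 3 (0.62 log units; beyond the scatter) and a 5.1-fold higher number from compound 1 to compound 3 (0.71 log units; beyond the scatter) as the two readings of this change. Among these three compounds, a halogen at this carbon, chloro and bromo alike, goes with the lower numbers, which the halogen swap alone could not show.

No supporting data bear on the origin of this loss. From the compounds shown here alone, whether a fluoro, methyl or methoxy group on this carbon would keep the affinity of compound 1 remains open.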